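Replacing Cyclohexyl with 4-Methoxyphenyl on the Amide Nitrogen

The source may hold more compounds than are shown below. What is called first, only, known or untested is meant among the compounds shown, and "the series" means these compounds.

Measured compounds:
compound 1, `CCOC(=O)C1=Cc2ccccc2OC1(OCc1cn(-c2ccc(F)cc2)nn1)C(F)(F)F`: 9100 nM
compound 2, `CCOC(=O)C1=Cc2ccccc2OC1(OCc1cn(-c2ccc(C)cc2)nn1)C(F)(F)F`: 26700 nM
compound 3, `CCOC(=O)C1=Cc2ccccc2OC1(OCc1cn(CC(=O)NC2CCCCC2)nn1)C(F)(F)F`: 12100 nM

In a functional assay on MCF7 cells (Homo sapiens) for inhibition, read by MTT assay, with a stated time of 24 h (a lower number here means a stronger inhibitor, a higher number a weaker inhibitor), compound 3 gives 12100 nM, the second highest of the three numbers. Its nearest neighbour is compound 1, with a 1.3-fold higher number from compound 1 to compound 3 (0.12 log units; within the scatter); its furthest is compound 2, with a 2.2-fold lower number from compound 2 to compound 3 (0.34 log units; beyond the scatter). Compound 4, `CCOC(=O)C1=Cc2ccccc2OC1(OCc1cn(CC(=O)Nc2ccc(OC)cc2)nn1)C(F)(F)F`, differs from compound 3 in one place: 4-methoxyphenyl in place of cyclohexyl on an amide-type nitrogen.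

Among the measured compounds shown here, none of the measured steps touches the amide-type nitrogen; the two that change the group on the aromatic nitrogen, a 2.9-fold higher number from compound 1 to compound 2 (0.47 log units; beyond the scatter) and a 1.3-fold higher number from compound 1 to compound 3 (0.12 log units; within the scatter), are at most modest. The whole set spans a narrow band, so no step beyond the scatter is expected in this assay. Compound 4 is therefore estimated at 11000 nM, within 4500 nM to 28000 nM, which means an expected 1.1-fold lower number from compound 3 to compound 4 (0.04 log units; within the scatter).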

Compound 4, half-maximal inhibitory concentration: 28100 nM
Estimate against measurement, compound 4: 2.6-fold (0.41 log units) below; the measured number lies above the stated range.
By their numbers in this assay, from the lowest: compounds 1 and 3 (each within the scatter of the next); then compounds 2 and 4 (each within the scatter of the next).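

In this assay, the amide-type nitrogen proves to be a position that responds: 4-methoxyphenyl in place of cyclohexyl gives a modest step (a 2.3-fold higher number from compound 3 to compound 4 (0.37 log units; beyond the scatter)). With this group in place, ((4-methoxyphenyl)carbamoyl)methyl on the aromatic nitrogen matches 4-methylphenyl within the scatter (a 1.1-fold higher number from compound 2 to compound 4 (0.02 log units; within the scatter)) but not 4-fluorophenyl (a 3.1-fold higher number from compound 1 to compound 4 (0.49 log units; beyond the scatter)). No measurement at hand explains the step at the amide-type nitrogen.

From the compounds shown here alone, whether that step follows the aromatic ring or the methoxy on it stays open. Phenyl or a 4-aminophenyl group on that nitrogen would begin to separate the two.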